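Phenyl in Place of Methyl on the Ether Oxygen

A few compounds are considered here, and "the series" means these few. Any claim that something is new, unique, unknown or untested is made for them only; others in the source may bear on it.

Compound 1, `COc1nc2ccccc2cc1/C=C/c1noc(-c2ccccc2Br)n1`, gives only a limit in an ADME assay on HepG2 cells (Homo sapiens) for cytotoxicity, read by sulforhodamine B assay, with a stated time of 48 h; on this read-out lower numbers stand for higher toxicity in this test and higher numbers for lower toxicity in this test: > 195000 nM.
Compound 2, `COCc1nc(/C=C/c2cc3ccccc3nc2OC)no1`, gives only a limit in this assay: > 270000 nM.

Within the data shown here, compound 2 thus stands at the limit of this assay, as does compound 1 at its own limit (the limit of > 195000 nM in this assay, at which 1 of the 2 values shown sits); the sole measured step, a step that the two limits leave unreadable from compound 1 to compound 2, cannot be read in size. Compound 3, `COc1nc2ccccc2cc1/C=C/c1noc(COc2ccccc2)n1`, differs from compound 2 by phenyl in place of methyl on an oxygen on a saturated carbon. Among the measured compounds shown here, no measured step bears on this change, and the only neighbouring step is unreadable. The estimate for compound 3 in this assay is 250000 nM, from 100000 nM to 400000 nM, most likely again a limit, with the expected step of an at least 1.0-fold lower number from compound 2 to compound 3 (0.03 log units; that floor lies within the scatter) within scatter.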

Compound 3, half-maximal cytotoxic concentration: > 220000 nM
Compound 3: no number, only a limit; the forecaster's own chance of this, stated with the estimate: 80%; the middle value is on the limit's open side.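

Among these compounds, compound 1, compound 2 and compound 3 all give only limits in this assay, and no step among them can be read. The compounds shown leave open whether any of these changes shifts the half-maximal cytotoxic concentration at all.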